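Triazole aryl swap on a shared core

A few compounds are considered here, and "the series" means these few. Any claim that something is new, unique, unknown or untested is made for them only; others in the source may bear on it.

Compound 2 `CCOc1ccccc1-n1nncc1CN1C(=O)C2(C(C#N)=C(N)Oc3c2c2nc4ccccc4nc2c2ccccc32)c2ccccc21` stands at the limit of an ADME assay on L02 cells (Homo sapiens) for antiproliferative activity, read by MTT assay, with a stated time of 48 h; on this read-out higher numbers stand for weaker inhibition and lower numbers for stronger inhibition: in this assay compound 2 gives > 50000 nM, a limit rather than a number. Compound 1 `N#CC1=C(N)Oc2c(c3nc4ccccc4nc3c3ccccc23)C12C(=O)N(Cc1cnnn1-c1ccc(Cl)cc1)c1ccccc12` likewise gives > 50000 nM in this assay, again a limit. The step that the two limits leave unreadable from compound 1 to compound 2 is thus unreadable, both values sitting at the limit of > 50000 nM in this assay, at which 2 of the 2 values shown sit. Compound 3 `N#CC1=C(N)Oc2c(c3nc4ccccc4nc3c3ccccc23)C12C(=O)N(Cc1cnnn1-c1ccc(N)cc1)c1ccccc12` differs from compound 2 by 4-aminophenyl in place of 2-ethoxyphenyl on an aromatic nitrogen. Among the measured compounds shown here, no measured step bears readably on this change, and the shared core shows no number in either case. Compound 3 is therefore expected to stay at the limit, a step that the limit leaves unreadable from compound 2 to compound 3. Compound 3 is estimated at 60000 nM in this assay.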

Compound 3, half-maximal inhibitory concentration: > 50000 nM
Compound 3 was reported as a limit; the forecaster's own chance of this, stated with the estimate: 85%; the middle value is on the limit's open side.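

In this assay, among the compounds shown here, compound 3 gives > 50000 nM, a limit, so no step from compound 1 or compound 2 to compound 3 can be read. The compounds shown leave open how these groups on the aromatic nitrogen compare, since every value rests on one limit: the limit of > 50000 nM in this assay, at which 3 of the 3 values shown sit.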